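Swapping Hydrogen for Fluoro on the Aromatic Ring

This account rests on a few compounds, and the source may have more. Where it says the series, first, only, none or still open, it means among the compounds named here.

Compound 2 `C/C(C(=O)NC1CC1)=C(\C)c1ccccc1` was tested in a toxicity assay on the whole organism (strain Icem-CET (SPF Caw)) for cytotoxicity, with Mus musculus as the target (on this read-out higher numbers stand for an effect only at larger amounts of compound and lower numbers for an effect already at smaller amounts), and gives 300 mg/kg. For the measured compounds named here, its only measured neighbour, compound 1 `COc1ccc(/C(C)=C(/C)C(=O)NC2CC2)cc1`, gives 300 mg/kg in this assay, so the two stand level. Going by the values given here, the single known step, no change at the digits printed from compound 1 to compound 2 (within the scatter), replaced a methoxy group on the same aromatic carbon and moved nothing beyond the scatter. Compound 3 `C/C(C(=O)NC1CC1)=C(\C)c1ccc(F)cc1` differs from compound 2 by fluoro in place of hydrogen on an aromatic carbon. Among the compounds with values here, because the one step at this position, no change at the digits printed from compound 1 to compound 2 (within the scatter), was flat, the change to compound 3 is expected to be no change at the digits printed from compound 2 to compound 3 (within the scatter). Compound 3 is therefore estimated at 300 mg/kg, with a range from 150 mg/kg to 600 mg/kg.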

Compound 3, dose for half-maximal effect: 600 mg/kg
Estimate against measurement, compound 3: 2.0-fold (0.30 log units) below; the range from low to high includes it.
By their numbers in this assay, from the lowest: compounds 1, 2 and 3 (each within the scatter of the next).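

In this assay, fluoro at this place, para to a large group, gives a 2.0-fold higher number from compound 2 to compound 3 (0.30 log units; within the scatter), and exchanging methoxy for fluoro on the same carbon gives a 2.0-fold higher number from compound 1 to compound 3 (0.30 log units; within the scatter). Hydrogen, methoxy and fluoro have now all stood at this position without any step going beyond the scatter. No measured evidence bears on this result. As far as these compounds go, whether an amine or a carboxylic acid on this carbon would move the number beyond the scatter remains open. So does what fluoro would do on another carbon of the ring.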